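Cytotoxicity notes: from compound 3 to compound 4

The source may hold more compounds than are shown below. What is called first, only, known or untested is meant among the compounds shown, and "the series" means these compounds.

The series is assessed in an ADME assay on Vero cells (Chlorocebus sabaeus) for cytotoxicity, read by MTT assay, with a stated time of 72 h; on this read-out higher numbers stand for lower toxicity in this test and lower numbers for higher toxicity in this test. Compound 1 `COC(=O)c1cc(-c2cccc(NC(=O)c3ccc(/C=C/C(=O)c4ccc(Cl)cc4)cc3)c2)on1` carries a 4-chlorophenyl on the carbonyl carbon; in this assay compound 1 returns only a limit, > 50 ug/mL. Compound 2 `COC(=O)c1cc(-c2cccc(NC(=O)c3ccc(/C=C/C(=O)c4ccc(F)cc4F)cc3)c2)on1` carries 2,4-difluorophenyl at that carbonyl carbon, and in this assay compound 2 likewise returns a limit, > 40 ug/mL. Compound 3 `COC(=O)c1cc(-c2cccc(NC(=O)c3ccc(/C=C/C(=O)c4ccccc4C)cc3)c2)on1` carries 2-methylphenyl there, and its reading in this assay is again a limit, > 25 ug/mL. With limits on both ends, the steps a step that the two limits leave unreadable from compound 1 to compound 2, a step that the two limits leave unreadable from compound 1 to compound 3 and a step that the two limits leave unreadable from compound 2 to compound 3 cannot be read for size or direction; the three readings sit at the limit of > 25 ug/mL in this assay, at which 1 of the 3 values shown sits, the limit of > 40 ug/mL in this assay, at which 1 of the 3 values shown sits, and (the limit of > 50 ug/mL in this assay, at which 1 of the 3 values shown sits), and compound 3 stands at the first of these, with nothing in the numbers to set it apart from compound 1 or compound 2.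

Compound 4 `COC(=O)c1cc(-c2cccc(NC(=O)c3ccc(/C=C/C(=O)c4cccc(OC)c4)cc3)c2)on1` differs from compound 3 by 3-methoxyphenyl in place of 2-methylphenyl on a carbonyl carbon. All three measured steps concern this same carbonyl position and all are unreadable, so they give no direction for this assay. No step beyond the scatter is expected, and a step that the limit leaves unreadable from compound 3 to compound 4 is the expected step. Compound 4 is estimated at 50 ug/mL in this assay, within 25 ug/mL to 100 ug/mL, most likely to be reported once more as a limit rather than a number.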

Compound 4, half-maximal cytotoxic concentration: > 100 ug/mL
Compound 4: no number, only a limit; the forecaster's own chance of this, stated with the estimate: 85%; middle value at least 2.0-fold (0.30 log units) from the limit.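

In this assay compound 4 returns only a limit, > 100 ug/mL. The steps from compound 1, compound 2 and compound 3 to compound 4 cannot be read for size or direction. The compounds shown leave open whether exchanging the aryl group on the carbonyl carbon shifts the cytotoxicity reading at all, and in which direction.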